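Pentyl ether on a hydroxypropyl side chain, two cores

A few compounds are considered here, and "the series" means these few. Any claim that something is new, unique, unknown or untested is made for them only; others in the source may bear on it.

Compound 1 `COc1ccc2cc(CCCO)oc(=O)c2c1` and compound 2 `CCCCCOCCCc1cc2ccc(OC)cc2c(=O)o1` share one core; compound 3 `COc1ccc2c(c1)C(=O)OC(CCCO)C2` and compound 4 `CCCCCOCCCC1Cc2ccc(OC)cc2C(=O)O1` share another. The difference between the two cores is not broken down here. In a functional assay on 786-0 cells (Homo sapiens) for antiproliferative activity, read by sulforhodamine B assay, with a stated time of 48 h (on this read-out lower numbers stand for stronger inhibition of growth and higher numbers for weaker inhibition of growth), compound 1 gives 26.9 ug/mL and compound 2 gives 25.5 ug/mL; the change pentyl in place of hydrogen on an oxygen on a saturated carbon gave a 1.1-fold lower number from compound 1 to compound 2 (0.02 log units; within the scatter). Compound 3 gives 102 ug/mL in this assay, the highest of the three numbers. The change pentyl in place of hydrogen on an oxygen on a saturated carbon is the same change, at the same place, as that from compound 1 to compound 2. Because the earlier step was a 1.1-fold lower number from compound 1 to compound 2 (0.02 log units; within the scatter), the step from compound 3 to compound 4 is expected to be of similar size, a 1.1-fold lower number from compound 3 to compound 4 (0.05 log units; within the scatter). Compound 4 is therefore estimated at 90 ug/mL in this assay, with an expected range of 45 ug/mL to 180 ug/mL.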

Compound 4, concentration for 50% growth inhibition: 31.9 ug/mL
For compound 4 the middle estimate is 2.8-fold (0.45 log units) above the measured one, and the stated range ends above it.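

In this assay the pentyl ether on the core of compound 3 gives a 3.2-fold lower number from compound 3 to compound 4 (0.50 log units; beyond the scatter), and the same change does not carry over at one size from one core to the other: the same change on two cores in this assay, a 1.1-fold lower number (0.02 log units; within the scatter) from compound 1 to compound 2 and a 3.2-fold lower number (0.50 log units; beyond the scatter) from compound 3 to compound 4, 3.0-fold (0.48 log units) apart, beyond the scatter of two such steps

Going by these compounds alone, the pair on the core of compound 1 alone would have given no sign of a step, so a step read on one core is a poor guide to the other. These two pairs do not show which feature of the cores sets the size of the step, or how it would run on a third core.

Open, from the compounds shown here alone, is whether the gap between the cores holds for other groups on that oxygen, such as a propyl or a decyl chain. Also open, going by these compounds, is how an amine at the end of the side chain would behave on each core.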